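Aryl replacement on the shared core in the agonist assay

The source may hold more compounds than are shown below. What is called first, only, known or untested is meant among the compounds shown, and "the series" means these compounds.

compound 1 `c1cc(-c2nccs2)c2c(c1)C(c1ncc[nH]1)CC2` in a functional assay on CHO cells for agonist activity at Alpha-1A adrenergic receptor (Homo sapiens), read by FLIPR and calcium flux; on this read-out lower numbers stand for an effect already at smaller amounts and higher numbers for an effect only at larger amounts of compound: 426 nM
compound 2 `Cc1ccc2c(c1NS(C)(=O)=O)CCC2c1ncc[nH]1` in this assay: 33 nM
compound 3 `Clc1ccc2c(c1-c1ccn[nH]1)CCC2c1ncc[nH]1` in this assay: 322 nM

Compound 1 gives the highest of the three numbers. The number of compound 3 lies within the usual scatter of that of compound 1, so the two cannot be ordered. The number of compound 2 stands apart from compound 1 by a gap beyond the scatter.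

Compound 4 `c1ccc(-c2cccc3c2CCC3c2ncc[nH]2)nc1` is not yet measured. It differs from compound 1 in one place: pyridin-2-yl in place of 1,3-thiazol-2-yl on an aromatic carbon. Within the data shown here, no measured pair changes only this group, so the size of the effect is open. The step from compound 1 to compound 4 is expected to be a 1.1-fold lower number from compound 1 to compound 4 (0.05 log units; within the scatter), none beyond the scatter. Compound 4 is therefore estimated at 380 nM, with a range from 130 nM to 1100 nM.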

Compound 4, half-maximal effective concentration: 1150 nM
Compound 4: middle estimate off by 3.0-fold (0.48 log units), on the low side, and the stated range ends below it.
By their numbers in this assay, from the lowest: compound 2; then compounds 3 and 1 (each within the scatter of the next); then compound 4.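

On an aromatic carbon of the shared core, the aryl group is not freely exchangeable: in this assay pyridin-2-yl in place of 1,3-thiazol-2-yl gives a 2.7-fold higher number from compound 1 to compound 4 (0.43 log units; beyond the scatter) and this is a step beyond the scatter. Among these compounds, this is the first single-place change that can be read, and it moves the number upward. No measurement at hand accounts for this step.

As far as these compounds go, it remains open how pyridin-3-yl or pyridin-4-yl would read at this place. From the compounds shown here alone, an amine or a morpholine ring there is equally open.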